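The source may hold more compounds than are shown below. What is called first, only, known or untested is meant among the compounds shown, and "the series" means these compounds.

Compound 1 (`CCCCn1cnc2c(NCc3cccc(Cl)c3)nc(N[C@H]3CC[C@H](N)CC3)nc21`) gives 10600 nM in a functional assay on HCC827 cells (Homo sapiens) for inhibition, read by fluorescence, with a stated time of 72 h; on this read-out lower numbers stand for stronger inhibition of growth and higher numbers for weaker inhibition of growth. For the measured compounds named here, compound 2 (`CCCCCCn1cnc2c(Nc3cccc(Cl)c3)nc(N[C@H]3CC[C@H](N)CC3)nc21`), the only other compound measured so far, gives 10200 nM. These two numbers lie within the usual scatter of repeated measurements, so compound 1 stands level with compound 2 on this read-out.

Compound 3 (`CCCCn1cnc2c(Nc3cc(OC)cc(OC)c3)nc(N[C@H]3CC[C@H](N)CC3)nc21`) has not yet been measured in this assay. It keeps the rest of compound 1 but carries 3,5-dimethoxyphenyl in place of 3-chlorobenzyl on a nitrogen on an aromatic ring.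

Going by the values given here, no measured pair of compounds differs in just one place, so the data offer no direct guide to the effect of this swap. The expectation is therefore cautious: a small move towards a lower number, which would mean somewhat stronger inhibition of growth, and it may not clear the scatter by much. The expected change is a 1.8-fold lower number from compound 1 to compound 3 (0.25 log units; within the scatter). For compound 3 the estimated value is 6000 nM, with an expected range of 1800 nM to 20000 nM.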

Compound 3, concentration for 50% growth inhibition: 20100 nM
Compound 3: the middle estimate sits 3.4-fold (0.53 log units) below what was measured; the measured number lies above the stated range.
By their numbers in this assay, from the lowest: compounds 2, 1 and 3 (each within the scatter of the next).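

Replacing 3-chlorobenzyl with 3,5-dimethoxyphenyl on a nitrogen on an aromatic ring gives a 1.9-fold higher number from compound 1 to compound 3 (0.28 log units; within the scatter) in this assay. For the compounds shown here, this is the first pair of compounds here that differs in just one place, and it shows that this position accepts a marked change in the group without separating the two compounds beyond ordinary measurement noise: the chlorine leaves, while two oxygens and two hydrogen-bond acceptors, as counted for the group, enter. Nothing available explains why the two compounds stand level on this read-out.

A single pair cannot show whether any group at this position can move the number clearly in either direction, or whether the effect of the swap would hold with a different chain on the shared core. A plain phenyl, a phenyl carrying one methoxy group, or a ring bearing an amine or a carboxylic acid would each test this position further, and the compounds shown leave open how such groups would compare with 3-chlorobenzyl.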